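This account rests on a few compounds, and the source may have more. Where it says the series, first, only, none or still open, it means among the compounds named here.

Measured in a functional assay on HL-60 cells (Homo sapiens) for inhibition, read by CCK-8 assay, with a stated time of 48 h, tested at 20 uM; on this read-out higher numbers stand for more inhibition of growth at the one concentration tested and lower numbers for less inhibition of growth:

Compound 1 `Cc1ccc(S(=O)(=O)Oc2ccccc2/C=C(\C#N)C(=O)Nc2nnc(Cc3cccc4ccccc34)s2)cc1`: 19%
Compound 2 `N#C/C(=C\c1ccccc1OS(=O)(=O)c1ccc([N+](=O)[O-])cc1)C(=O)Nc1nnc(Cc2cccc3ccccc23)s1`: 18%
Compound 3 `N#C/C(=C\c1ccccc1OS(=O)(=O)c1ccc(F)cc1)C(=O)Nc1nnc(Cc2cccc3ccccc23)s1`: 12%

Compound 2 stands within the scatter of both other compounds, as two steps show: a number 1 percentage points lower from compound 1 to compound 2 (within the scatter) and a number 6 percentage points lower from compound 2 to compound 3 (within the scatter). Compound 4 `Cc1ccc(Cc2nnc(NC(=O)/C(C#N)=C/c3ccccc3OS(=O)(=O)c3ccc([N+](=O)[O-])cc3)s2)cc1` differs from compound 2 in one place: 4-methylphenyl in place of naphthalen-1-yl on a saturated chain carbon bound to an aromatic carbon. This puts 4-methylphenyl in place of naphthalen-1-yl on a saturated chain carbon bound to an aromatic carbon. Those two steps, like a number 7 percentage points lower from compound 1 to compound 3 (within the scatter), change a different group, so none tests this swap directly. All three steps are small, and no change beyond the scatter is expected, though this is uncertain. The expected step is a number 2 percentage points higher from compound 2 to compound 4 (within the scatter). Compound 4 is estimated at 20%, with an expected range from 6% to 38%.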

Compound 4, percent growth inhibition at one concentration: 17%
Estimate against measurement, compound 4: 3 percentage points above; low and high end bracket the measured number.
By their numbers in this assay, from the lowest: compounds 3, 4, 2 and 1 (each within the scatter of the next).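

Among the compounds shown here, the earlier steps all changed a different group, so this is the first direct test of the saturated chain carbon bound to an aromatic carbon. In this assay, 4-methylphenyl in place of naphthalen-1-yl gives a number 1 percentage points lower from compound 2 to compound 4 (within the scatter) and so one six-membered aromatic ring in place of two leaves the read-out within the scatter. No measured evidence here explains this result. Still open, going by these compounds, is whether a non-aromatic group at this place, such as an amine or a longer chain, would give a step beyond the scatter.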